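The compounds below may be only part of what the source reports. "The series", "measured", "known", "first", "only" and "open" are said of these compounds alone.

Three compounds have so far been examined in a physicochemical assay for solubility, with a stated time of 24 h, at pH 2.2; on this read-out higher numbers stand for higher solubility and lower numbers for lower solubility. Compound 1 `COC(=O)c1ccc2ccc(C(=O)N(C)C)c-2cc1` returns only a limit of that assay, namely > 64 ug/mL. Compound 2 `CN(C)C(=O)c1ccc2cccccc1-2` likewise returns only a limit in this assay, > 43 ug/mL. Compound 3 `CN(C)C(=O)c1cn(C)c2ccccc12` also returns only a limit in this assay, > 51 ug/mL. Compound 1 differs from compound 2 by methoxycarbonyl in place of hydrogen on an aromatic carbon; the step that the two limits leave unreadable from compound 2 to compound 1 cannot be read because the limit of > 43 ug/mL in this assay, at which 1 of the 3 values shown sits, and the limit of > 64 ug/mL in this assay, at which 1 of the 3 values shown sits, bound both values from one side only. The difference between the core of compound 2 and the core of compound 3 is not broken down here. Compound 4 `COC(=O)c1ccc2c(C(=O)N(C)C)cn(C)c2c1` has yet to be measured; it differs from compound 3 by methoxycarbonyl in place of hydrogen on an aromatic carbon, the same kind of change as that from compound 2 to compound 1, though here the place is a six-membered aromatic ring of carbon only, meta to a fused ring and para to a fused ring, rather than a seven-membered aromatic ring of carbon only. The step that the limit leaves unreadable from compound 3 to compound 4 is expected to be small, resting on compound 3 sitting at the limit of > 51 ug/mL in this assay, at which 1 of the 3 values shown sits, and on the earlier change of this kind leaving compound 1 at the limit of > 64 ug/mL in this assay, at which 1 of the 3 values shown sits. Compound 4 is therefore estimated at 60 ug/mL, with an expected range from 20 ug/mL to 200 ug/mL.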

Compound 4, solubility: 50 ug/mL
For compound 4 the middle estimate is 1.2-fold (0.08 log units) above the measured one; low and high end bracket the measured number.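

In this assay, methoxycarbonyl in place of hydrogen on an aromatic carbon, carried to the core of compound 3, gives an at least 1.0-fold lower number from compound 3 to compound 4 (0.00 log units; that floor lies within the scatter). That step is a floor and not a size, since compound 3 stands only at a limit: the limit of > 51 ug/mL in this assay, at which 1 of the 4 values shown sits. It shows that compound 4 returns a measured number on this core, but it neither shows nor excludes a real drop, and it does not show that the change acts alike on both cores: the step on the core of compound 2 cannot be read, and no two step sizes stand to be compared.

The compounds shown carry only methoxycarbonyl at this kind of place, and it stays open whether a carboxylic acid or an amine on the same aromatic carbon would return a number or a limit in this assay. Also open, from the compounds shown here alone, is what a longer chain in place of the dimethylamide would give on either core.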